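The compounds below may be only part of what the source reports. "The series", "measured", "known", "first", "only" and "open" are said of these compounds alone.

Measured in a functional assay on HepG2 cells (Homo sapiens) for antiproliferative activity, read by MTT assay, with a stated time of 72 h; a lower number here means a stronger inhibitor, a higher number a weaker inhibitor:
- compound 1 `O=C1COc2ccc(-c3cccc(NS(=O)(=O)c4ccc(F)cc4)c3)cc2N1`: > 40000 nM
- compound 2 `COc1ncc(-c2ccc3c(c2)NC(=O)CO3)cc1NS(=O)(=O)c1ccc(F)cc1`: 6590 nM

Compound 1 has no numerical value in this assay: its > 40000 nM is a limit of the assay. Compound 2 gives a number, 6590 nM.

The next compound to be tested is compound 3 `COc1cccc(N2C(=O)COc3ccc(-c4cccc(NS(=O)(=O)c5ccc(F)cc5)c4)cc32)c1`, which has 3-methoxyphenyl in place of hydrogen on an amide-type nitrogen in a ring. Among the compounds with values here, no measured pair shows this change, so its size cannot be read from the data. A moderate step towards stronger inhibition in this assay is expected, though this remains tentative and compound 3 may also stay at the limit. The expected change is an at least 3.3-fold lower number from compound 1 to compound 3 (0.52 log units; beyond the scatter), an estimate only. For compound 3 the estimated value is 12000 nM. The expected range runs from 3000 nM to 40000 nM.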

Compound 3, half-maximal inhibitory concentration: > 40000 nM
Compound 3 gave a limit, no number; the forecaster's own chance of this, stated with the estimate: 30%; middle value at least 3.3-fold (0.52 log units) away from the limit.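

Compound 1 and compound 3 both give only a limit in this assay, so no step can be read for 3-methoxyphenyl in place of hydrogen: the limit of > 40000 nM in this assay, at which 2 of the 3 values shown sit.

The compounds shown leave open how far either compound lies beyond that limit, and so what this change does to the value.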